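This account rests on a few compounds, and the source may have more. Where it says the series, first, only, none or still open, it means among the compounds named here.

In a functional assay on Gurav cells (Homo sapiens) for inhibition, read by sulforhodamine B assay (on this read-out higher numbers stand for weaker inhibition of growth and lower numbers for stronger inhibition of growth), compound 1 `FC(F)(F)Oc1ccc(-c2ccc(-c3ccc(-c4nc5ccccc5[nH]4)cc3)cc2)cc1` gives 100000 nM and compound 2 `CN(C)c1ccc(-c2ccc(-c3ccc(-c4nc5ccccc5[nH]4)cc3)cc2)cc1` gives 100000 nM, level with each other and together the highest of the three numbers, while compound 3 `Clc1cccc(-c2ccc(-c3ccc(-c4nc5ccccc5[nH]4)cc3)cc2)c1` gives 2190 nM. Compound 4 `CN(C)c1ccc(-c2ccc(-c3ccc(-c4nc5c(O)cccc5[nH]4)cc3)cc2)cc1` differs from compound 2 by hydroxy in place of hydrogen on an aromatic carbon, with hydroxy in place of hydrogen on an aromatic carbon. Among the compounds with values here, two measured steps bear on this only indirectly: no change at the digits printed from compound 1 to compound 2 (within the scatter), and a 46-fold lower number from compound 2 to compound 3 (1.66 log units; beyond the scatter). Neither alters the 1H-benzimidazol-2-yl, so neither gives the size of this change. With compound 2 at 100000 nM, only a moderate fall in this assay is expected, and no fall remains possible. The expected change is a 3.3-fold lower number from compound 2 to compound 4 (0.52 log units; beyond the scatter). Compound 4 is estimated at 30000 nM, within a range of 3000 nM to 100000 nM.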

Compound 4, concentration for 50% growth inhibition: 8210 nM
Compound 4: the middle estimate sits 3.7-fold (0.56 log units) above what was measured, within the range that was stated.
By their numbers in this assay, from the lowest: compound 3; then compound 4; then compounds 1 and 2 (each within the scatter of the next).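

In this assay, within the data shown here, changing 1H-benzimidazol-2-yl to 4-hydroxy-1H-benzimidazol-2-yl gives a 12-fold lower number from compound 2 to compound 4 (1.09 log units; beyond the scatter), whereas the earlier steps left this group unchanged. The step shows that this position responds strongly to a hydroxy group of a single heavy atom, even with the 4-(dimethylamino)phenyl group kept. Nothing given here accounts for the size of this change.

On these data alone, it remains open whether methoxy or an amine at this position would give a similar step. As far as these compounds go, it is also open whether hydroxy would have a like effect on compound 3, which carries 3-chlorophenyl.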